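A few compounds are considered here, and "the series" means these few. Any claim that something is new, unique, unknown or untested is made for them only; others in the source may bear on it.

Compound 1 `O=C(CCCCC1CCSS1)NCc1cn(CCCOc2ccc3ccc(=O)oc3c2)nn1` carries a cyclic disulfide on a chain that ends in an amide, linked through a triazole to a coumarin-type fragment; compound 3 `O=C(CCCCC1CCSS1)NCc1cn(CCCCCOc2ccc3ccc(=O)oc3c2)nn1` keeps those parts but the difference between its core and that of compound 1 is not broken down here. Compound 2 `CC(=O)c1cc2ccc(OCCCn3cc(CNC(=O)CCCCC4CCSS4)nn3)cc2oc1=O` is compound 1 with acetyl in place of hydrogen on an aromatic carbon, and compound 4 `CC(=O)c1cc2ccc(OCCCCCn3cc(CNC(=O)CCCCC4CCSS4)nn3)cc2oc1=O` is compound 3 with acetyl in place of hydrogen on an aromatic carbon, so the same change is made on both cores.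

In a functional assay on PC-12 cells (Rattus norvegicus) for cytotoxicity, read by MTT assay, with stated times of 3 h and 2 h, tested at 0.1 uM (a lower number here means a weaker effect, a higher number a stronger effect of the compound at the concentration tested), compound 1 gives 37.8% and compound 2 gives 34.6%, a step of a number 3.2 percentage points lower from compound 1 to compound 2 (within the scatter). Compound 3 gives 46.3%, a number within the scatter of compound 1 and beyond it only against compound 2, which stands lower.

Because the same acetyl-for-hydrogen change gave a number 3.2 percentage points lower from compound 1 to compound 2 (within the scatter) on the core of compound 1, the step for compound 4 is expected to be about a number 3.3 percentage points lower from compound 3 to compound 4 (within the scatter). Compound 4 is therefore estimated at 43%, with a likely range from 33% to 53%.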

Compound 4, a percentage reported as activity, at one concentration (the size of the read-out at that concentration, not a potency): 28.9%
The estimate for compound 4 lay 14.1 percentage points above the measured number, outside the stated range (below it).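

On the core of compound 3, acetyl in place of hydrogen on an aromatic carbon gives a number 17.4 percentage points lower from compound 3 to compound 4 (beyond the scatter) in this assay. The size of this step therefore did not carry over from one core to the other, and a step measured on one core was a poor guide to the step on the other: the same change on two cores in this assay, a number 3.2 percentage points lower (within the scatter) from compound 1 to compound 2 and a number 17.4 percentage points lower (beyond the scatter) from compound 3 to compound 4, 14.2 percentage points apart, beyond the scatter of two such steps. Among these compounds, this does not show why the two steps differ, and with only two pairs and the first step within the scatter, it does not establish that the change lowers the number on every core.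

The compounds shown leave open whether a different group at the same place, such as an amine or a carboxylic acid, would also give steps that differ between the two cores. They also leave open how the acetyl step would behave on a core with a longer chain than that of compound 3, and, as each number comes from one concentration, whether the weaker effect seen with compound 4 at that concentration would also appear at other concentrations.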